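This account rests on a few compounds, and the source may have more. Where it says the series, first, only, none or still open, it means among the compounds named here.

Three compounds sharing one core have numbers in a physicochemical assay for lipophilicity, at pH 7.4; on this read-out higher numbers stand for higher lipophilicity and lower numbers for lower lipophilicity. Compound 1 `CC(C)CN(C1CCc2ccc(F)cc21)S(=O)(=O)c1ccc2c(c1)C(=O)CC(C1CCOCC1)O2` gives 4.03, compound 2 `CC(C)CN(c1cccc(F)c1)S(=O)(=O)c1ccc2c(c1)C(=O)CC(C1CCOCC1)O2` gives 3.5, and compound 3 `CC(C)CN(c1ccc(C(C)(C)C)cc1)S(=O)(=O)c1ccc2c(c1)C(=O)CC(C1CCOCC1)O2` gives 4.97, the highest of the three and clear of both others beyond the scatter.

Compound 4 `CC(C)CN(c1ccccc1F)S(=O)(=O)c1ccc2c(c1)C(=O)CC(C1CCOCC1)O2` has not been measured. It differs from compound 3 by 2-fluorophenyl in place of 4-(tert-butyl)phenyl on a sulfonamide nitrogen, which puts 2-fluorophenyl in place of 4-(tert-butyl)phenyl on a sulfonamide nitrogen.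

The closest measured guide is the large step of a number 1.47 log units higher from compound 2 to compound 3 (beyond the scatter), where 4-(tert-butyl)phenyl replaces 3-fluorophenyl at that same nitrogen. Compound 4 would run this swap in reverse, with the fluorine at a different ring position. Among the compounds with values here, no measured compound here carries 2-fluorophenyl, so that difference remains untested. The modest step of a number 0.94 log units higher from compound 1 to compound 3 (beyond the scatter) involves a different group and helps less.

A large fall is therefore expected, similar in size to the step to compound 2. The expected step is a number 1.52 log units lower from compound 3 to compound 4 (beyond the scatter). For compound 4 the estimate is 3.45, with an expected range of 3.05 to 3.85.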

Compound 4, distribution coefficient: 3.44
The estimate for compound 4 lay 0.01 log units above the measured number, and the stated range covers the measured number.
By their numbers in this assay, from the lowest: compounds 4 and 2 (each within the scatter of the next); then compound 1; then compound 3.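

In this assay, putting 2-fluorophenyl in place of 3-fluorophenyl on the sulfonamide nitrogen gives a number 0.06 log units lower from compound 2 to compound 4 (within the scatter), so this read-out does not separate these two fluorophenyl groups at this position. Compound 4 also stands apart from the other two compounds, with a number 1.53 log units lower from compound 3 to compound 4 (beyond the scatter) on losing 4-(tert-butyl)phenyl and a number 0.59 log units lower from compound 1 to compound 4 (beyond the scatter) on losing 6-fluoro-2,3-dihydro-1H-inden-1-yl, so the separation seen for compound 2 also holds for a second fluorophenyl group. Nothing available here explains these differences.

On these data alone, it remains open how a phenyl ring carrying an amine or a carboxylic acid would compare with the two fluorophenyl groups on this nitrogen. As far as these compounds go, whether these steps would keep their size with a different shared core also remains open.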